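Dichlorophenyl Analogue and Expected Cytotoxicity on MT4 Cells

The source may hold more compounds than are shown below. What is called first, only, known or untested is meant among the compounds shown, and "the series" means these compounds.

The measured compounds, with their numbers in an ADME assay on MT4 cells (Homo sapiens) for cytotoxicity, read by MTT assay, with a stated time of 4 days; on this read-out higher numbers stand for lower toxicity in this test and lower numbers for higher toxicity in this test:
Compound 1, `Cc1cc(-c2ccc(F)cc2)cc(C)c1Nc1ccnc(Nc2ccc(C#N)cc2)n1`, gives 4170 nM.
Compound 2, `Cc1cc(-c2ccccc2)cc(C)c1Nc1ccnc(Nc2ccc(C#N)cc2)n1`, gives 4170 nM.
Compound 3, `Cc1cc(-c2ccccc2C(F)(F)F)cc(C)c1Nc1ccnc(Nc2ccc(C#N)cc2)n1`, gives 4210 nM.

Compound 2 shares its number with compound 1 at the digits given; the step from compound 1 to compound 2 is no change at the digits printed from compound 1 to compound 2 (within the scatter). Its most distant neighbour is compound 3, and that step is a 1.0-fold higher number from compound 2 to compound 3 (0.00 log units; within the scatter). The three numbers thus sit together, all within the scatter of one another.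

The unmeasured compound is compound 4, `Cc1cc(-c2cc(Cl)cc(Cl)c2)cc(C)c1Nc1ccnc(Nc2ccc(C#N)cc2)n1`. It differs from compound 2 in one place: 3,5-dichlorophenyl in place of phenyl on an aromatic carbon.

For the measured compounds named here, two measured steps bear on this change. Replacing hydrogen with trifluoromethyl on an aromatic carbon gave a 1.0-fold higher number from compound 2 to compound 3 (0.00 log units; within the scatter), and replacing fluoro with hydrogen on an aromatic carbon gave no change at the digits printed from compound 1 to compound 2 (within the scatter); the step from compound 1 to compound 3 was a 1.0-fold higher number from compound 1 to compound 3 (0.00 log units; within the scatter). Every substitution on this phenyl so far left the number where it was. Compound 4 is therefore expected to show a 1.0-fold higher number from compound 2 to compound 4 (0.00 log units; within the scatter), no step beyond the scatter in either direction. For compound 4 the estimate is 4200 nM, in the range 2500 nM to 7000 nM.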

Compound 4, half-maximal cytotoxic concentration: 4290 nM
Beside the measured number, compound 4's estimate is 1.0-fold (0.01 log units) below it; the measured number falls inside the stated range.
By their numbers in this assay, from the lowest: compounds 1, 2, 3 and 4 (each within the scatter of the next).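

In this assay the 3,5-dichlorophenyl group, with two chlorine atoms on the ring, stands within the scatter of all three earlier compounds: the result is a 1.0-fold higher number from compound 2 to compound 4 (0.01 log units; within the scatter) and a 1.0-fold higher number from compound 3 to compound 4 (0.01 log units; within the scatter) and also a 1.0-fold higher number from compound 1 to compound 4 (0.01 log units; within the scatter). The aromatic carbon that lies meta to two methyl groups has thus now carried a phenyl ring with no substituent, with one and with two, and chloro joins fluoro and trifluoromethyl among the substituents that leave this number within the scatter. No measurement at hand explains why the number holds so steady across these rings.

The substituents shown on this phenyl are all fluoro, trifluoromethyl or chloro, so what an amine or a carboxylic acid on the same ring would do to the number remains an open question. Also open, from the compounds shown here alone, is whether the number would stay within the scatter if a longer chain took the place of the whole ring on that aromatic carbon.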